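The compounds below may be only part of what the source reports. "The series", "measured", "known", "first", "only" and "open" are said of these compounds alone.

Compound 1 `CCCn1ccc2cc(-c3ccc(OC)nc3)cc(Cl)c2c1=O` stands highest of the two measured compounds in a functional assay on CHO cells for agonist activity at metabotropic glutamate receptor 2 (Homo sapiens), read by GTPgammaS binding; a higher number here means a larger maximal response, a lower number a smaller maximal response: compound 1 gives 121%, while compound 2 `CCCn1ccc2cc(-c3cnc(OC)c(F)c3)cc(Cl)c2c1=O` gives 75% in this assay, a step of a number 46 percentage points lower from compound 1 to compound 2 (beyond the scatter). Compound 3 `CCCn1ccc2cc(-c3ccc(OCc4cccnc4)nc3)cc(Cl)c2c1=O` differs from compound 1 by pyridin-3-yl in place of hydrogen on a saturated chain carbon bound to an oxygen on an aromatic ring. Among the compounds with values here, the single measured step is a change of another kind at another place; no measured step bears directly on this change, and the expectation rests on compound 1 alone. A step of a number 11 percentage points lower from compound 1 to compound 3 (beyond the scatter) is expected, not beyond the scatter in either direction. Compound 3 is thus estimated at 110%, between 65% and 145%.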

Compound 3, largest response reached (Emax), in percent of the reference or control that the assay uses: 120%
The estimate for compound 3 lay 10 percentage points below the measured number, and the stated range covers the measured number.
By their numbers in this assay, from the lowest: compound 2; then compounds 3 and 1 (each within the scatter of the next).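

Replacing the methoxy of compound 1 with (pyridin-3-yl)methoxy gives, in this assay, a number 1 percentage points lower from compound 1 to compound 3 (within the scatter). The position on a saturated chain carbon bound to an oxygen on an aromatic ring thus accepts a pyridin-3-yl group with the maximal response held within the scatter. Nothing available explains why the response holds at this position.

On these data alone, whether a phenyl, an amine or a carboxylic acid at the same carbon would also hold the response remains open. So does whether a fluoro group on the methoxypyridine ring of compound 3 would lower the response as it does in compound 2.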